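Chloro on the fused ring: cytotoxicity notes, series 1 to 4

A few compounds are considered here, and "the series" means these few. Any claim that something is new, unique, unknown or untested is made for them only; others in the source may bear on it.

Measured so far in an ADME assay on NIH3T3 cells (Mus musculus) for cytotoxicity, read by MTT assay, with a stated time of 24 h; a lower number here means a stronger inhibitor, a higher number a weaker inhibitor:
compound 1 `Cc1cc(-c2nc3cc(Cl)ccc3o2)ccc1NC(=O)CN1CCN(CCN(C)C)CC1`: compound 1 gives 19200 nM
compound 2 `Cc1cc(-c2nc3ccccc3o2)ccc1NC(=O)CN1CCN(CCN(C)C)CC1`: compound 2 gives 63500 nM
compound 3 `Cc1cc(-c2nc3ccccc3o2)ccc1NC(=O)CCl`: compound 3 gives 12200 nM

Compound 2 and compound 1 carry the same side chain and differ in one place only: chloro in place of hydrogen on an aromatic carbon. That single change yields a 3.3-fold lower number from compound 2 to compound 1 (0.52 log units; beyond the scatter).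

Compound 3 carries a different side chain from compound 2; the difference between the two cores is not broken down here. Compound 3 shows the lowest number of the three, but its gap to compound 1 lies within the scatter, so no order between compound 3 and compound 1 is claimed. Its gap to compound 2 lies beyond the scatter.

Compound 4 `Cc1cc(-c2nc3cc(Cl)ccc3o2)ccc1NC(=O)CCl` has not yet been measured. It stands to compound 3 as compound 1 stands to compound 2: chloro in place of hydrogen on an aromatic carbon. On these data alone, the place is described in the same words for both pairs, so this is the same change, made twice, once measured and once still open.

In this assay the step is expected to be a 2.4-fold lower number from compound 3 to compound 4 (0.39 log units; beyond the scatter), a little smaller than the measured one, resting on a 3.3-fold lower number from compound 2 to compound 1 (0.52 log units; beyond the scatter) and on the fact that the side chain of compound 3 differs from that of compound 2, so a one-to-one transfer is not assured. For compound 4 the estimate is 5000 nM, with an expected range from 2000 nM to 12000 nM.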

Compound 4, half-maximal inhibitory concentration: 8640 nM
Compound 4: the middle estimate sits 1.7-fold (0.24 log units) below what was measured; low and high end bracket the measured number.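

In this assay, chloro in place of hydrogen on an aromatic carbon gives a 1.4-fold lower number from compound 3 to compound 4 (0.15 log units; within the scatter), a step that cannot be told from the scatter of repeated measurements, whereas the same change on the core and side chain of compound 2 gives a 3.3-fold lower number from compound 2 to compound 1 (0.52 log units; beyond the scatter), which lies beyond it. Set side by side, the two steps cannot be separated: the same change on two cores in this assay, a 3.3-fold lower number (0.52 log units; beyond the scatter) from compound 2 to compound 1 and a 1.4-fold lower number (0.15 log units; within the scatter) from compound 3 to compound 4, 2.3-fold (0.37 log units) apart, within the scatter of two such steps The pairs are therefore compatible with one shared step of modest size, but two pairs do not establish that the change carries over one-to-one, nor do they show that the side chain alters its size.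

Still open, on these data alone, is how a fluoro, bromo or methoxy group on the same aromatic carbon would compare with chloro in this assay. Equally open is whether the chloro step would hold with a side chain other than the two shown here, such as a longer chain ending in a carboxylic acid or a simple primary amine.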